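A Sulfur Side Chain Change at the Assay Limit

The compounds below may be only part of what the source reports. "The series", "measured", "known", "first", "only" and "open" are said of these compounds alone.

In a functional assay on HT-29 cells (Homo sapiens) for inhibition, read by MTT assay, with a stated time of 48 h (on this read-out lower numbers stand for stronger inhibition and higher numbers for weaker inhibition), compound 1 `COc1cc(-c2nnc(S)n2-c2ccc(N(C)C)cc2)cc(OC)c1OC` gives > 60000 nM, a limit of the assay. Compound 2 `COc1cc(-c2nnc(SC)n2-c2ccc(N(C)C)cc2)cc(OC)c1OC` gives > 60000 nM, also a limit. Compound 3 `COc1ccc(CSc2nnc(-c3cc(OC)c(OC)c(OC)c3)n2-c2ccc(N(C)C)cc2)cc1` gives > 60000 nM, likewise a limit, so no number is available for it. Compound 4 `COc1cc(-c2nnc(SCC(=O)c3ccccc3)n2-c2ccc(N(C)C)cc2)cc(OC)c1OC` carries benzoyl in place of 4-methoxyphenyl on a saturated chain carbon bound to a sulfur. The closest measured changes are a step that the two limits leave unreadable from compound 2 to compound 3 and a step that the two limits leave unreadable from compound 1 to compound 3, and neither offers a size. With only these to go on, no shift beyond the scatter is expected in this assay. The estimated step is a number no higher from compound 3 to compound 4 (the limit leaves the size open). Compound 4 is expected at 60000 nM, with an estimated range of 10000 nM to 120000 nM.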

Compound 4, half-maximal inhibitory concentration: 45200 nM
For compound 4 the middle estimate is 1.3-fold (0.12 log units) above the measured one; the measured number falls inside the stated range.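

In this assay, going by these compounds alone, compound 4, with benzoyl on the saturated chain carbon bound to a sulfur, is the first compound here to give a number rather than a limit, and the others remain at that limit: the limit of > 60000 nM in this assay, at which 3 of the 4 values shown sit. Against them, only floors can be read: an at least 1.3-fold lower number from compound 3 to compound 4 (0.12 log units; that floor lies within the scatter) and an at least 1.3-fold lower number from compound 2 to compound 4 (0.12 log units; that floor lies within the scatter) and an at least 1.3-fold lower number from compound 1 to compound 4 (0.12 log units; that floor lies within the scatter). This change at this position therefore brings the value into readable range, but it shows no shift beyond the scatter.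

On these data alone, what an amine or a carboxylic acid on the saturated chain carbon bound to a sulfur, or a longer chain on that sulfur, would give in this assay remains open.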